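Piperidin-1-yl in place of ethyl(methyl)amino

The compounds below may be only part of what the source reports. "The series", "measured", "known", "first", "only" and "open" are said of these compounds alone.

Within the data shown here, in a functional assay for antagonist activity, with Cavia porcellus as the target (a higher number here means a weaker inhibitor, a lower number a stronger inhibitor), compound 1 `CN(CC#CCCC1(C(O)(c2ccccc2)c2ccccc2)SCCCS1)Cc1ccccc1` gives 3170 nM and compound 2 `CCN(C)CC#CCCC1(C(O)(c2ccccc2)c2ccccc2)SCCCS1` gives 1230 nM as the lowest number so far. Among the measured compounds shown here, the only measured step, a 2.6-fold lower number from compound 1 to compound 2 (0.41 log units; beyond the scatter), replaced phenyl with methyl on a saturated chain carbon bound to an amine nitrogen, and it is modest though beyond the scatter. Compound 3 `OC(c1ccccc1)(c1ccccc1)C1(CCC#CCN2CCCCC2)SCCCS1` has piperidin-1-yl in place of ethyl(methyl)amino on a saturated chain carbon bound to a triple-bonded carbon. For the measured compounds named here, no measured compound carries this ring, so the step to compound 2 offers only a sense of scale for a change around the amine nitrogen. An estimated step of a 1.2-fold lower number from compound 2 to compound 3 (0.09 log units; within the scatter) in this assay is therefore small, with only a weak lean in direction. For compound 3 the expected value is 1000 nM within an estimated range of 400 nM to 2500 nM in this measurement.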

Compound 3, antagonist equilibrium constant: 1000 nM
The estimate for compound 3 equals the measured number at the digits printed; low and high end bracket the measured number.
By their numbers in this assay, from the lowest: compounds 3 and 2 (each within the scatter of the next); then compound 1.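

In this assay, the step to a ring at this position cannot be told apart from the scatter, with a 1.2-fold lower number from compound 2 to compound 3 (0.09 log units; within the scatter), so among the compounds shown, piperidin-1-yl on a saturated chain carbon bound to a triple-bonded carbon serves as well as the open ethyl(methyl)amino group. Replacing benzyl(methyl)amino with the same ring gives a 3.2-fold lower number from compound 1 to compound 3 (0.50 log units; beyond the scatter), so compound 1, with its benzyl(methyl)amino group, stands apart from both compound 2 and compound 3, and none of the three goes against this. Nothing given here offers an explanation for these differences.

As far as these compounds go, whether a pyrrolidine ring, a morpholine ring or a dimethylamino group would sit with compound 2 and compound 3 remains open. So does whether a longer chain between the triple bond and the amine would keep these numbers.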